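Nitro for hydroxy: carrying a measured step to compound 4

A few compounds are considered here, and "the series" means these few. Any claim that something is new, unique, unknown or untested is made for them only; others in the source may bear on it.

Measured compounds and their values in a functional assay on MDA-MB-231 cells (Homo sapiens) for antiproliferative activity, read by sulforhodamine B assay, with a stated time of 48 h; a higher number here means a weaker inhibitor, a lower number a stronger inhibitor:

compound 1, `COc1ccc(C(=O)/C=C\Nc2ccc(-c3nc4cc(OC)c(OC)c(OC)c4s3)cc2C)cc1O`; compound 1 gives 12400 nM
compound 2, `COc1cc(OC)c2sc(-c3ccc(N/C=C\C(=O)c4ccc(OC)c(O)c4)cc3)nc2c1`; compound 2 gives 7610 nM
compound 3, `COc1ccc(C(=O)/C=C\Nc2ccc(-c3nc4cc(OC)c(OC)c(OC)c4s3)cc2C)cc1[N+](=O)[O-]`; compound 3 gives 12400 nM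

Compound 1 and compound 3 differ in one place only, (nitro in place of hydroxy on an aromatic carbon). The step this makes in this assay is no change at the digits printed from compound 1 to compound 3 (within the scatter), so the exchange has left the read-out where it was.

Compound 2 shares its methoxy-bearing ring and the hydroxy group with compound 1, but the difference between the two cores is not broken down here. Their values in this assay sit within the scatter of one another, so no order between compound 1 and compound 2 can be read from them.

Compound 4, `COc1cc(OC)c2sc(-c3ccc(N/C=C\C(=O)c4ccc(OC)c([N+](=O)[O-])c4)cc3)nc2c1`, has not yet been measured. It differs from compound 2 by nitro in place of hydroxy on an aromatic carbon. The surroundings of the exchanged group read the same, word for word, as in the pair of compound 1 and compound 3, so this is the same change made on the core of compound 2.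

The expectation for compound 4 rests on compound 3, whose step no change at the digits printed from compound 1 to compound 3 (within the scatter) showed no movement beyond the scatter. The corresponding step is therefore expected to be small as well, a 1.1-fold higher number from compound 2 to compound 4 (0.02 log units; within the scatter). Compound 4 is estimated to give 8000 nM in this assay, with a likely range from 3500 nM to 18000 nM.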

Compound 4, half-maximal inhibitory concentration: 12900 nM
Estimate against measurement, compound 4: 1.6-fold (0.21 log units) below; low and high end bracket the measured number.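

In this assay, nitro in place of hydroxy on the core of compound 2 gives a 1.7-fold higher number from compound 2 to compound 4 (0.23 log units; within the scatter), and the step can be set beside the one on the core of compound 1: the same change on two cores in this assay, no change at the digits printed (within the scatter) from compound 1 to compound 3 and a 1.7-fold higher number (0.23 log units; within the scatter) from compound 2 to compound 4, 1.7-fold (0.23 log units) apart, within the scatter of two such steps. On these two pairs, then, the change from 3-hydroxy-4-methoxyphenyl to 4-methoxy-3-nitrophenyl carries from one core to the other with neither step beyond the scatter and no measurable difference between them. This does not show that the two groups are interchangeable across the series, since it rests on two pairs only, and with two steps this small it gives no direction for the exchange and cannot test whether a larger effect would transfer between cores in the same way.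

Still open, going by these compounds, is whether other groups on this aromatic carbon, such as an amine, a carboxylic acid or a fluorine atom, would stay equally close to the hydroxy and nitro compounds on both cores. Also open, on these data alone, is how the two cores compare with each other, as they differ in more than one place, and whether the flat picture holds when the neighbouring methoxy group gives way to a longer alkoxy chain.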